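The source may report more compounds than this note shows. Statements on the series, on what has been measured and on what is new or still open speak of the compounds shown alone.

Working notes on the series, read in a functional assay on SMMC-7721 cells (Homo sapiens) for cytotoxicity, read by MTT assay, with a stated time of 72 h; a higher number here means a weaker inhibitor, a lower number a stronger inhibitor. Compound 1 `CCOC(=O)c1ccc(NC(=O)CSC(=S)N[C@H]2CCOC2=O)cc1` gives 64900 nM. Compound 2 `O=C(CSC(=S)N[C@H]1CCOC1=O)Nc1ccc(C(=O)/C=C/c2ccccc2)cc1` gives > 128000 nM, which is a limit of the assay and not a number. The standing of compound 2 therefore rests only on (the limit of > 128000 nM in this assay, at which 1 of the 2 values shown sits).

For the measured compounds named here, the one measured step is an at least 1.9-fold higher number from compound 1 to compound 2 (0.29 log units; that floor lies within the scatter), with 2-phenylethenyl in place of ethoxy on a carbonyl carbon. Compound 3 `O=C(CSC(=S)N[C@H]1CCOC1=O)Nc1ccc(C(=O)/C=C/c2cccc(Cl)c2)cc1` keeps that 2-phenylethenyl arm but has chloro in place of hydrogen on an aromatic carbon, meta to a large group, so that phenyl becomes 3-chlorophenyl: chloro in place of hydrogen on an aromatic carbon.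

Going by the values given here, no measured step covers a change of this kind on the ring. The step to compound 2 bears on it only by fixing the starting point, and it gives no size for the new change. A step beyond the scatter is therefore not expected in either direction, and the expected step is an at least 1.0-fold lower number from compound 2 to compound 3 (0.02 log units; that floor lies within the scatter). The estimate for compound 3 is 120000 nM, with an expected range of 55000 nM to 220000 nM.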

Compound 3, half-maximal inhibitory concentration: 39100 nM
The estimate for compound 3 lay 3.1-fold (0.49 log units) above the measured number, outside the stated range (below it).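

For the compounds shown here, on the 2-phenylethenyl arm, chloro in place of hydrogen on an aromatic carbon, meta to a large group, gives the first step that lies beyond the scatter in this assay (an at least 3.2-fold lower number from compound 2 to compound 3 (0.51 log units; beyond the scatter)), so this place on the ring is one at which the read-out responds. As far as these compounds go, that step is only a floor, and its true size stays unknown because compound 2 gives a limit of the assay and not a number: (the limit of > 128000 nM in this assay, at which 1 of the 3 values shown sits). The whole 2-(3-chlorophenyl)ethenyl arm in place of ethoxy gives (a 1.7-fold lower number from compound 1 to compound 3 (0.22 log units; within the scatter)), so in this assay compound 3 and compound 1 stand within the scatter of each other, and the gain from chloro does not set compound 3 apart from the ethyl ester.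

From the compounds shown here alone, whether the response belongs to chloro or to any substituent at this place remains open, as fluoro, methoxy, an amine or a carboxylic acid on the same carbon would be needed to tell. Also open, going by these compounds, is whether chloro on another carbon of that ring, or a longer chain in place of the ethenyl link, would give a step of similar size.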